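Removing the aryl-bearing substituent from a shared core

The compounds below may be only part of what the source reports. "The series", "measured", "known", "first", "only" and "open" are said of these compounds alone.

Compound 1, `CCOC(=O)C1=C(NN=C(C(C)=O)C(C)=O)Nc2[nH]nc(C)c2C1c1ccc(N(C)C)cc1`: 9740 nM
Compound 2, `CCOC(=O)C1=C(N/N=C(/Cl)c2ccc([N+](=O)[O-])cc2)Nc2[nH]nc(C)c2C1c1ccc(N(C)C)cc1`: 52700 nM
Compound 3, `CCOC(=O)C1=C(N/C=N/c2ccccn2)Nc2[nH]nc(C)c2C1c1ccc(N(C)C)cc1`: 37300 nM

The three measured compounds share one core and differ only in the group on an amine nitrogen. In a functional assay on MCF7 cells (Homo sapiens) for inhibition, read by MTT assay, with a stated time of 48 h (a higher number here means a weaker inhibitor, a lower number a stronger inhibitor), compound 1 gives 9740 nM, compound 2 gives 52700 nM and compound 3 gives 37300 nM. Compound 3 stands second highest of the three numbers: a 3.8-fold higher number from compound 1 to compound 3 (0.58 log units; beyond the scatter), while a 1.4-fold lower number from compound 2 to compound 3 (0.15 log units; within the scatter).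

Compound 4, `CCOC(=O)C1=C(N)Nc2[nH]nc(C)c2C1c1ccc(N(C)C)cc1`, is not yet measured. It differs from compound 3 by a hydrogen atom in place of a group of 8 heavy atoms (6 carbon, 2 nitrogen; one six-membered aromatic ring with 1 hetero atom), on an amine nitrogen. Within the data shown here, no measured step strips a substituent down to hydrogen, so the steps that bear on it only loosely are a 5.4-fold higher number from compound 1 to compound 2 (0.73 log units; beyond the scatter) and a 3.8-fold higher number from compound 1 to compound 3 (0.58 log units; beyond the scatter), both modest exchanges of one group for another. They give no direction for a bare hydrogen on that nitrogen, and the step from compound 3 may fall within the scatter or reach a modest size either way. Compound 4 is therefore expected to give an estimated 30000 nM in this assay, with a wide range from 8000 nM to 100000 nM. The expected step is a 1.2-fold lower number from compound 3 to compound 4 (0.09 log units; within the scatter).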

Compound 4, half-maximal inhibitory concentration: 5060 nM
Compound 4: the middle estimate sits 5.9-fold (0.77 log units) above what was measured, outside the stated range (below it).
By their numbers in this assay, from the lowest: compounds 4 and 1 (each within the scatter of the next); then compounds 3 and 2 (each within the scatter of the next).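

In this assay, a hydrogen atom on this amine nitrogen gives a 7.4-fold lower number from compound 3 to compound 4 (0.87 log units; beyond the scatter) and also a 10-fold lower number from compound 2 to compound 4 (1.02 log units; beyond the scatter), so the ring-bearing groups of compound 3 and compound 2 go with clearly higher numbers than the bare position. The ring-free group of compound 1 does not follow them, with a 1.9-fold lower number from compound 1 to compound 4 (0.28 log units; within the scatter), so that group and hydrogen cannot be told apart here, and none of the three groups shown gives a number beyond the scatter below that of hydrogen. Nothing available here accounts for these differences.

Going by these compounds, whether a methyl group, an acetyl group or a longer alkyl chain on this nitrogen would fall with compound 4 or with compound 3 remains open. Also open, on these data alone, is whether a simple phenyl ring on this nitrogen would go with the higher numbers.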